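Amide nitrogen substituent exchange in the cytotoxicity series

The compounds below may be only part of what the source reports. "The series", "measured", "known", "first", "only" and "open" are said of these compounds alone.

Compound 1 `C=CC1=C(C(=O)O)C(c2ccc(F)cc2)OC1` carries a free carboxylic acid on the shared core. In a functional assay on HeLa cells (Homo sapiens) for cytotoxicity, read by MTT assay, with a stated time of 24 h (a higher number here means a weaker inhibitor, a lower number a stronger inhibitor), compound 1 gives 67400 nM. Compound 2 `C=CC1=C(C(=O)NCC(C)C)C(c2ccc(F)cc2)OC1` has isobutylamino in place of hydroxy on the carbonyl carbon. In this assay compound 2 reaches only a limit of the assay, > 100000 nM. The step of an at least 1.4-fold higher number from compound 1 to compound 2 (0.17 log units; that floor lies within the scatter) is therefore known only at its floor, and compound 2 stands at the limit of > 100000 nM in this assay, at which 1 of the 2 values shown sits, so its position on the numbers is a bound, not a point.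

Compound 3 `C=CC1=C(C(=O)Nc2ccccc2)C(c2ccc(F)cc2)OC1` differs from compound 2 by phenyl in place of isobutyl on an amide-type nitrogen. For the measured compounds named here, the only measured step, from compound 1 to compound 2, exchanges the group on the carbonyl carbon and not the group on the amide-type nitrogen; no measured pair swaps one amide substituent for another, so the weight of that step for the present change is indirect. With compound 2 already at the limit, compound 3 is expected to stay in the same weak region, with a step that the limit leaves unreadable from compound 2 to compound 3 not beyond the scatter. Compound 3 is estimated at 120000 nM, within 40000 nM to 400000 nM, and a limit rather than a number is the more likely outcome.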

Compound 3, half-maximal inhibitory concentration: > 100000 nM
Compound 3: no number, only a limit; the forecaster's own chance of this, stated with the estimate: 65%; the middle value lies beyond the limit too.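

In this assay compound 3 also gives only a limit of the assay, > 100000 nM. The step between the two amides cannot be read, so this position shows no readable difference for phenyl in place of isobutyl on the amide-type nitrogen, and an aromatic ring there leaves the amide at the same limit as the branched chain: the limit of > 100000 nM in this assay, at which 2 of the 3 values shown sit. Measured against the free acid, anilino in place of hydroxy on the carbonyl carbon gives an at least 1.4-fold higher number from compound 1 to compound 3 (0.17 log units; that floor lies within the scatter), which is known only at its floor, and that floor is the same one printed for isobutylamino.

Whether any amide on the shared core can give a number inside the range of the assay stays open, since both nitrogen substituents shown are carbon-only groups, and a substituent bearing an amine or a carboxylic acid, or a longer chain, would test this. How far compound 2 and compound 3 actually lie from the limit, and whether either differs from compound 1 by more than the scatter, also remains unresolved.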